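The compounds below may be only part of what the source reports. "The series", "measured", "known", "first", "only" and "open" are said of these compounds alone.

Measured compounds in a functional assay on SW-620 cells (Homo sapiens) for antiproliferative activity, read by MTT assay, with a stated time of 72 h; on this read-out higher numbers stand for weaker inhibition and lower numbers for stronger inhibition:
- compound 1 `O=C1NC(O)(CCn2cnc3cncc(Br)c32)C(OCc2ccccc2)=C1OCc1ccccc1`: > 100000 nM
- compound 2 `COc1nc(OC)c2c(ccn2CCC2(O)NC(=O)C(OCc3ccccc3)=C2OCc2ccccc2)n1`: 90700 nM
- compound 3 `O=C1O/C(=C\Cn2cnc3ccn(C/C=C4\OC(=O)C(OCc5ccccc5)=C4OCc4ccccc4)c3c2=O)C(OCc2ccccc2)=C1OCc1ccccc1`: 47200 nM

The value given for compound 1 is a limit of the assay, not a number; compound 1 is one of the entries sitting at the limit of > 100000 nM in this assay, at which 1 of the 3 values shown sits. Compound 2 and compound 3 each return a number, and the gap between their two values lies within the usual scatter of repeated measurements, so no order between them is read. All three share the same core carrying two benzyloxy groups.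

The step from compound 1 to compound 4 `Nc1nc(F)c(Cl)c2c1ncn2CCC1(O)NC(=O)C(OCc2ccccc2)=C1OCc1ccccc1` changes the heteroaromatic group on the saturated chain carbon: a group of 12 heavy atoms (6 carbon, 4 nitrogen, 1 fluorine, 1 chlorine; one five-membered aromatic ring with 2 hetero atoms, one six-membered aromatic ring with 1 hetero atom) in place of a group of 10 heavy atoms (6 carbon, 3 nitrogen, 1 bromine; one five-membered aromatic ring with 2 hetero atoms, one six-membered aromatic ring with 1 hetero atom), on a saturated chain carbon, two bonds along the chain from a saturated ring carbon. Going by the values given here, no measured pair differing in one place is available, so no step size is known from the data. Given that compound 1 returns only a limit and that the other two compounds sit in the same weak region, the expectation for compound 4 is a value near the upper end of the measured range, with the step of an at least 1.1-fold lower number from compound 1 to compound 4 (0.07 log units; that floor lies within the scatter) expected to be small relative to the scatter. Compound 4 is thus estimated at 85000 nM, with a range of 30000 nM to 200000 nM.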

Compound 4, half-maximal inhibitory concentration: 59000 nM
Beside the measured number, compound 4's estimate is 1.4-fold (0.16 log units) above it; the measured number falls inside the stated range.
By their numbers in this assay, from the lowest: compounds 3, 4 and 2 (each within the scatter of the next). At a limit, above all of these: compound 1.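

Going by these compounds alone, compound 4 gives the series its only readable step at this position, on a saturated chain carbon, two bonds along the chain from a saturated ring carbon: in this assay the change of heteroaromatic group reads as an at least 1.6-fold lower number from compound 1 to compound 4 (0.22 log units; that floor lies within the scatter). From the compounds shown here alone, that step is only a floor, so it shows neither a gain nor the absence of one, and the true size of the change stays unknown. Compound 1 remains a limit of the assay, not a number: the limit of > 100000 nM in this assay, at which 1 of the 4 values shown sits.

The change swaps bromine for fluorine and chlorine and also adds a hydrogen-bond donor, and no pair shown separates these parts. Going by these compounds, whether a longer chain at this position, or a carboxylic acid on the heteroaromatic group, would move the number clear of the scatter remains open.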